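A few compounds are considered here, and "the series" means these few. Any claim that something is new, unique, unknown or untested is made for them only; others in the source may bear on it.

Measured in a functional assay on A549 cells (Homo sapiens) for antiproliferative activity, read by MTT assay, with a stated time of 72 h; a higher number here means a weaker inhibitor, a lower number a stronger inhibitor:

- Compound 1 `O=C(N/N=C/c1ccccc1)Nc1ccc(Oc2ccnc3[nH]ccc23)c(F)c1`: 2500 nM
- Compound 2 `O=C(N/N=C/c1ccc(F)cc1)Nc1ccc(Oc2ccnc3[nH]ccc23)c(F)c1`: 680 nM
- Compound 3 `O=C(N/N=C/c1ccc(O)cc1)Nc1ccc(Oc2ccnc3[nH]ccc23)c(F)c1`: 3760 nM

Compound 3 carries the highest number of the three, but it cannot be separated from compound 1, as a 1.5-fold higher number from compound 1 to compound 3 (0.18 log units; within the scatter) shows. Compound 2 is clearly apart from it, with a 5.5-fold higher number from compound 2 to compound 3 (0.74 log units; beyond the scatter).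

The next compound is compound 4 `O=C(N/N=C/c1cc(Br)c(O)c(Br)c1)Nc1ccc(Oc2ccnc3[nH]ccc23)c(F)c1`, which keeps the shared core and changes only the aryl group: 3,5-dibromo-4-hydroxyphenyl in place of 4-hydroxyphenyl on a carbon with a double bond to nitrogen. In words, 3,5-dibromo-4-hydroxyphenyl stands in place of 4-hydroxyphenyl on a carbon with a double bond to nitrogen.

Going by the values given here, no bromo compound has been measured, so the closest evidence is indirect. Halogen on the ring has one precedent, in compound 2, with a 3.7-fold lower number from compound 1 to compound 2 (0.57 log units; beyond the scatter), a modest step towards a lower number. Hydroxy alone did little in compound 3, with a 1.5-fold higher number from compound 1 to compound 3 (0.18 log units; within the scatter), so the retained hydroxy gives no reason to expect a shift of its own. A modest step towards a lower number in this assay is therefore expected, though with real uncertainty. The expected change is a 3.4-fold lower number from compound 3 to compound 4 (0.53 log units; beyond the scatter). For compound 4 the estimated value is 1100 nM, with an expected range from 350 nM to 3500 nM.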

Compound 4, half-maximal inhibitory concentration: 16200 nM
Compound 4: the middle estimate sits 15-fold (1.17 log units) below what was measured, outside the stated range (above it).
By their numbers in this assay, from the lowest: compound 2; then compounds 1 and 3 (each within the scatter of the next); then compound 4.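

At this position, on a carbon with a double bond to nitrogen, placing two bromine atoms on the 4-hydroxyphenyl group raises the number in this assay beyond the scatter, with a 4.3-fold higher number from compound 3 to compound 4 (0.63 log units; beyond the scatter), whereas hydroxy alone had stayed within the scatter of phenyl. The 3,5-dibromo-4-hydroxyphenyl group also stands clearly apart from plain phenyl, with a 6.5-fold higher number from compound 1 to compound 4 (0.81 log units; beyond the scatter), which makes compound 4 the weakest of the four. Halogen on this aryl group therefore does not act in one direction: the 4-fluorophenyl of compound 2 goes with a lower number than phenyl, compound 4 goes against that, and the gap between these two halogen-bearing compounds is the widest in the set, with a 24-fold higher number from compound 2 to compound 4 (1.38 log units; beyond the scatter), while nothing available here accounts for the direction of the change.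

The compounds shown leave open whether the bromine atoms alone go with the higher number or only do so together with the hydroxy, a question that 3,5-dibromophenyl or a single bromo on the ring would address. Also open, as far as these compounds go, is how a methoxy or an amine in place of the hydroxy would read in this assay.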